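This account rests on a few compounds, and the source may have more. Where it says the series, first, only, none or still open, it means among the compounds named here.

Compound 3 `Cn1ccc2c(Oc3ccc(NC(=O)c4cc5cccnc5n(-c5ccc(Cl)cc5)c4=O)cc3F)ccnc21` was tested in a functional assay on HT-29 cells (Homo sapiens) for antiproliferative activity, read by MTT assay, with a stated time of 72 h (on this read-out higher numbers stand for weaker inhibition and lower numbers for stronger inhibition), where compound 3 gives 220 nM. For the measured compounds named here, that is the highest of the three numbers measured so far, but the spread is small: compound 2 `Cn1ccc2c(Oc3ccc(NC(=O)c4cc5cccnc5n(-c5ccc(F)cc5)c4=O)cc3F)ccnc21` gives 160 nM. Compound 1 `O=C(Nc1ccc(Oc2ccnc3[nH]ccc23)c(F)c1)c1cc2cccnc2n(-c2ccc(Br)cc2)c1=O` carries a bromo group on its pendant phenyl ring and differs from compound 3 in two places; compound 1 gives 120 nM.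

The next compound, compound 4 `Cn1ccc2c(Oc3ccc(NC(=O)c4cc5cccnc5n(-c5ccc(Br)cc5)c4=O)cc3F)ccnc21`, is reached from compound 3 by a single change: bromo in place of chloro on an aromatic carbon. Going by the values given here, only one measured step touches the same position, the replacement of fluoro by chloro, which gave a 1.4-fold higher number from compound 2 to compound 3 (0.14 log units; within the scatter). That step lay within the scatter, and swapping chloro for bromo is a change of the same kind at the same place, so no movement beyond the scatter is expected here either. Compound 1 also bears the bromo group at that position, though on a different core, and its value of 120 nM sits close to that of compound 3.

Taken together, compound 4 is estimated to give 200 nM in this assay, with a plausible range from 100 nM to 400 nM, which corresponds to an expected step of a 1.1-fold lower number from compound 3 to compound 4 (0.04 log units; within the scatter).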

Compound 4, half-maximal inhibitory concentration: 330 nM
Compound 4: the middle estimate sits 1.7-fold (0.22 log units) below what was measured; measured number inside the range.
By their numbers in this assay, from the lowest: compounds 1, 2, 3 and 4 (each within the scatter of the next, the first and the last beyond it).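

On the shared core, bromo in place of chloro gives a 1.5-fold higher number from compound 3 to compound 4 (0.18 log units; within the scatter), so this change on its own stays inside the scatter, as the change from fluoro to chloro did. For the compounds shown here, the two steps run the same way, however, and bromo in place of fluoro gives a 2.1-fold higher number from compound 2 to compound 4 (0.31 log units; beyond the scatter), the first step at this position to pass beyond the scatter, though only modestly. Compound 4 also provides the first comparison with compound 1 that differs in one place: with the 4-bromophenyl group held fixed, methyl in place of hydrogen on an aromatic nitrogen gives a 2.8-fold higher number from compound 1 to compound 4 (0.44 log units; beyond the scatter), a modest step and the widest among these compounds.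

Nothing available here accounts for either of these steps.

The compounds shown leave open how an amine, a methoxy group or a carboxylic acid at this position would read in this assay alongside the three halogens. On these data alone, it also remains open whether methyl in place of hydrogen on that nitrogen gives a similar step when the pendant ring carries the 4-chlorophenyl pattern or a fluoro group instead of bromo.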